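Replacing an Aminomethyl Arm with an Ethylcarbamoyl Group

A few compounds are considered here, and "the series" means these few. Any claim that something is new, unique, unknown or untested is made for them only; others in the source may bear on it.

Three compounds have been measured in a functional assay on HCT-116 cells (Homo sapiens) for inhibition; a lower number here means a stronger inhibitor, a higher number a weaker inhibitor:
Compound 1 `CCNC(=O)c1noc(-c2cc(C(C)C)c(O)cc2O)c1-c1cc(CN)no1` gives 84 nM.
Compound 2 `CCNC(=O)c1noc(-c2cc(C(C)C)c(O)cc2O)c1-c1cc(CNC(C)=O)no1` gives 167 nM.
Compound 3 `CCNC(=O)c1noc(-c2cc(C(C)C)c(O)cc2O)c1-c1cc(CN(C)C)no1` gives 92 nM.

Compound 3 holds the second highest of the three numbers; its nearest neighbour is compound 1 and its furthest is compound 2, and both gaps lie within the scatter. The next step leads to compound 4 `CCNC(=O)c1cc(-c2c(C(=O)NCC)noc2-c2cc(C(C)C)c(O)cc2O)on1`, where the change is ethylcarbamoyl in place of (dimethylamino)methyl on an aromatic carbon.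

Among the measured compounds shown here, no measured step touches this exact change. The three known steps, a 2.0-fold higher number from compound 1 to compound 2 (0.30 log units; within the scatter), a 1.1-fold higher number from compound 1 to compound 3 (0.04 log units; within the scatter) and a 1.8-fold lower number from compound 2 to compound 3 (0.26 log units; within the scatter), all keep the (dimethylamino)methyl or aminomethyl arm and only vary what sits on its nitrogen, and each of them stayed within the scatter. They show that this part of the shared core has accepted a hydrogen, an acetyl and two methyls on the nitrogen without a clear shift in this assay. Since compound 4 removes the arm altogether and puts an ethylcarbamoyl group directly on the ring carbon, the data give no firm direction, so the expected step is small and uncertain: a 1.4-fold higher number from compound 3 to compound 4 (0.15 log units; within the scatter) is the estimate. Compound 4 is therefore expected to give about 130 nM, with a range from 50 nM to 350 nM.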

Compound 4, half-maximal inhibitory concentration: 14 nM
Beside the measured number, compound 4's estimate is 9.3-fold (0.97 log units) above it; the whole stated range lies above it.
By their numbers in this assay, from the lowest: compound 4; then compounds 1, 3 and 2 (each within the scatter of the next).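

In this assay, swapping the arm for ethylcarbamoyl on this aromatic carbon, next to the ring nitrogen, gives a 6.6-fold lower number from compound 3 to compound 4 (0.82 log units; beyond the scatter), and the same replacement of the other two arms gives a 6.0-fold lower number from compound 1 to compound 4 (0.78 log units; beyond the scatter) and a 12-fold lower number from compound 2 to compound 4 (1.08 log units; beyond the scatter). All three steps lie beyond the scatter, so compound 4 is the strongest inhibitor of the four, whereas changing only the substituents on the arm's nitrogen had produced no step beyond the scatter; this position is therefore sensitive to what is attached to the ring carbon, even though it tolerated those nitrogen changes. No available evidence accounts for this gain.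

The compounds shown leave open which part of the ethylcarbamoyl group carries the gain, the carbonyl, the amide hydrogen or the ethyl chain. They also leave open how a primary carboxamide, a methylcarbamoyl group, a longer chain on the amide nitrogen or a carboxylic acid at this ring carbon would compare with compound 4.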